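The source may hold more compounds than are shown below. What is called first, only, known or untested is meant among the compounds shown, and "the series" means these compounds.

Values in an ADME assay on Caco-2 cells (Homo sapiens) for inhibition, read by MTT assay, with a stated time of 72 h (a higher number here means a weaker inhibitor, a lower number a stronger inhibitor), each one a limit of the assay and not a number:

- Compound 1 `COc1cc(/C=C/C(=O)/C=C(/C=C/c2ccc(OC(C)=O)c(OC)c2)NC2CCCCC2)ccc1OC(C)=O`: > 25000 nM
- Compound 2 `CCCNC(=C\C(=O)/C=C/c1ccc(O)c(OC)c1)/C=C/c1ccc(O)c(OC)c1`: > 25000 nM
- Compound 3 `COc1cc(/C=C/C(=O)/C=C(/C=C/c2ccc(OC(C)=O)c(OC)c2)NCC(C)C)ccc1OC(C)=O`: > 25000 nM

Compound 3 therefore has no exact position on the scale, only its limit. The same holds across the series, which shows (the limit of > 25000 nM in this assay, at which 3 of the 3 values shown sit).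

Compound 4 `CCC(C)NC(=C\C(=O)/C=C/c1ccc(OC(C)=O)c(OC)c1)/C=C/c1ccc(OC(C)=O)c(OC)c1` differs from compound 3 by a single swap of groups: sec-butyl in place of isobutyl on an amine nitrogen. In words, this is sec-butyl in place of isobutyl on an amine nitrogen, and the two compounds have the same atoms, joined differently.

For the measured compounds named here, the one measured step that bears on this change is a step that the two limits leave unreadable from compound 1 to compound 3, with isobutyl in place of cyclohexyl on an amine nitrogen. It gives no size to build on. No step beyond the scatter is expected in this assay, in either direction, because of the limit of > 25000 nM in this assay, at which 3 of the 3 values shown sit. The estimated step is a step that the limit leaves unreadable from compound 3 to compound 4. A limit is also the most likely report. For compound 4 the estimated value is 30000 nM, with an expected range from 15000 nM to 60000 nM.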

Compound 4, half-maximal inhibitory concentration: > 25000 nM
Compound 4 ended at the assay's limit (the forecaster's own chance of this, stated with the estimate: 85%); the middle value is on the limit's open side.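

No step can be read between compound 1, compound 3 and compound 4, as each value is only a limit: the limit of > 25000 nM in this assay, at which 4 of the 4 values shown sit. As far as these compounds go, whether cyclohexyl, isobutyl or sec-butyl on the amine nitrogen makes any difference in this assay stays open, as does what concentration would actually reach half-maximal inhibition.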